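Working notes: hydroxy for methyl on a double-bonded nitrogen

A few compounds are considered here, and "the series" means these few. Any claim that something is new, unique, unknown or untested is made for them only; others in the source may bear on it.

Measured in a functional assay on MCF7 cells (Homo sapiens) for antiproliferative activity, with a stated time of 5 days; a lower number here means a stronger inhibitor, a higher number a weaker inhibitor:
- compound 1 `CCCCc1ccc2[nH]c(-c3ccc(OC)cc3)c(C=O)c2c1`: 22 nM
- compound 2 `CCCCc1ccc2[nH]c(-c3ccc(OC)cc3)c(/C=N\C)c2c1`: 27 nM
- compound 3 `CCCCCc1ccc2[nH]c(-c3ccc(OC)cc3)c(/C=N\C)c2c1`: 21 nM

Compound 2 stands at 27 nM, within the scatter of both other values. The next structure is compound 4 `CCCCc1ccc2[nH]c(-c3ccc(OC)cc3)c(/C=N\O)c2c1`, which carries hydroxy in place of methyl on a double-bonded nitrogen. Among the measured compounds shown here, two measured steps bear on this only indirectly. The group on the aromatic carbon was changed in a 1.2-fold higher number from compound 1 to compound 2 (0.09 log units; within the scatter), and the chain was lengthened in a 1.3-fold lower number from compound 2 to compound 3 (0.11 log units; within the scatter). Neither step left the scatter, and neither tests this exchange directly, so no step beyond the scatter is expected in this assay. The estimated step is a 1.1-fold lower number from compound 2 to compound 4 (0.03 log units; within the scatter). For compound 4 the expected value is 25 nM, with an estimated range of 10 nM to 65 nM.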

Compound 4, half-maximal inhibitory concentration: 212 nM
For compound 4 the middle estimate is 8.5-fold (0.93 log units) below the measured one; measured number above the stated range.
By their numbers in this assay, from the lowest: compounds 3, 1 and 2 (each within the scatter of the next); then compound 4.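

In this assay, among the compounds shown here, the group on the double-bonded nitrogen is the first place where a change goes beyond the scatter: hydroxy in place of methyl gives (a 7.9-fold higher number from compound 2 to compound 4 (0.89 log units; beyond the scatter)). The group on the aromatic carbon is therefore not freely exchangeable, since the same comparison with the carbonyl of compound 1 gives (a 9.6-fold higher number from compound 1 to compound 4 (0.98 log units; beyond the scatter)), although compound 1 and compound 2 lie within the scatter of each other. Nothing available accounts for this loss.

Open, on these data alone, is whether methoxy or ethyl on that nitrogen would track compound 2 or compound 4.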